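This account rests on a few compounds, and the source may have more. Where it says the series, first, only, none or still open, it means among the compounds named here.

Measured so far in a functional assay on cells for antagonist activity at C-C chemokine receptor type 1 (Homo sapiens), read by FLIPR and calcium flux; a lower number here means a stronger inhibitor, a higher number a weaker inhibitor:
- compound 1, `Cc1c(C(=O)NCc2cccc(O)c2)cnn1-c1ccc(Cl)cc1`: > 3000 nM
- compound 2, `Cc1c(C(=O)NCc2cccc(N)c2)cnn1-c1ccc(Cl)cc1`: > 3000 nM

Compound 1 gives only a limit of the assay, not a number, in this assay. Compound 2 likewise gives only a limit in this assay, > 3000 nM, so its standing is known only as a ceiling, not as a point. The step that the two limits leave unreadable from compound 1 to compound 2 is therefore unreadable, because of the limit of > 3000 nM in this assay, at which 2 of the 2 values shown sit. Compound 3, `Cc1c(C(=O)NCc2cccc(S(C)(=O)=O)c2)cnn1-c1ccc(Cl)cc1`, differs from compound 2 by methylsulfonyl in place of amino on an aromatic carbon. Among the measured compounds shown here, no measured step bears on this change, since the one step available is itself unreadable. Compound 3 is therefore expected to sit near the same limit, with the step that the limit leaves unreadable from compound 2 to compound 3 being little more than a placeholder. The estimate for compound 3 is 5000 nM, within a range from 1500 nM to 20000 nM, and a reported limit rather than a number remains the likelier outcome.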

Compound 3, half-maximal inhibitory concentration: 2100 nM
Compound 3: middle estimate off by 2.4-fold (0.38 log units), on the high side; low and high end bracket the measured number.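

In this assay compound 3 gives 2100 nM, so methylsulfonyl on this aromatic carbon, meta to a large group, yields a number. With hydroxy and amino on that carbon, compound 1 and compound 2 gave only limits of the assay. In place of amino, the change is an at least 1.4-fold lower number from compound 2 to compound 3 (0.15 log units; that floor lies within the scatter), and in place of hydroxy, it is an at least 1.4-fold lower number from compound 1 to compound 3 (0.15 log units; that floor lies within the scatter). On these data alone, each of these is only a floor, and the true size of both steps stays unknown because one end of each is a limit: the limit of > 3000 nM in this assay, at which 2 of the 3 values shown sit.

As far as these compounds go, neither floor clears the scatter, so it remains open whether methylsulfonyl truly gives a lower number than hydroxy or amino at this position. Also open, from the compounds shown here alone, is what a carboxylic acid or a sulfonamide would give on the same aromatic carbon.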